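The compounds below may be only part of what the source reports. "The series", "measured", "known", "first", "only" and "open" are said of these compounds alone.

Compound 1 `COC1CN(C(=O)/C=C/c2ccncc2-c2ccc3ccccc3c2)C1` is the starting point of this account. In a functional assay on KB cells (Homo sapiens) for inhibition, read by sulforhodamine B assay, with a stated time of 72 h (a lower number here means a stronger inhibitor of growth, a higher number a weaker inhibitor of growth), compound 1 gives only a limit, > 10000 nM, and no number. Going by the values given here, compound 2 `Cn1ccc2cc(-c3cnccc3/C=C/C(=O)O)ccc21`, the other compound measured so far, carries a carboxy group on a different aromatic part. In this assay compound 2 likewise gives only a limit, > 10000 nM. Where compound 1 stands is therefore told by a single fact: the limit of > 10000 nM in this assay, at which 2 of the 2 values shown sit. Among the compounds with values here, no measured step separates the two compounds, so no direction or size of change can be read from them. Compound 3 `O=C(O)/C=C/c1ccncc1-c1ccc2ccccc2c1` has not yet been measured. It differs from compound 1 by hydroxy in place of 3-methoxyazetidin-1-yl on a carbonyl carbon; cut one bond further out, the change reads (3-methoxyazetidin-1-yl)carbonyl to carboxy. Because compound 2, which also carries a carboxy group, gives > 10000 nM, compound 3 is expected to sit at the limit too. The step that the limit leaves unreadable from compound 1 to compound 3 is expected to be none beyond the scatter. Compound 3 is estimated at 15000 nM in this assay, in a range from 5000 nM to 50000 nM.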

Compound 3, concentration for 50% growth inhibition: > 10000 nM
Compound 3: no number, only a limit (the forecaster's own chance of this, stated with the estimate: 80%); the middle value lies beyond the limit too.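

In this assay compound 3 gives > 10000 nM, which is a limit and not a number. Going by these compounds alone, compound 1 also gives only a limit, so no step from compound 1 to compound 3 can be read. The compounds shown leave open how far each lies beyond that limit, and whether hydroxy and 3-methoxyazetidin-1-yl on the carbonyl carbon differ at all: the limit of > 10000 nM in this assay, at which 3 of the 3 values shown sit.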